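A few compounds are considered here, and "the series" means these few. Any claim that something is new, unique, unknown or untested is made for them only; others in the source may bear on it.

Working notes on the aryl group at the sulfonyl sulfur. In a functional assay (trachea) for antagonist activity, with Cavia porcellus as the target (on this read-out higher numbers stand for higher potency (the scale is a negative logarithm) and lower numbers for lower potency), compound 1 `COc1ccc(OC)c(S(=O)(=O)NC(=O)c2ccc(Cn3ccc4ccc(NC(=O)CC5CCCC5)cc43)c(OC)c2)c1` gives 9.1, the highest of the three numbers in hand. Among the compounds with values here, compound 2 `CCCCC(CC)C(=O)Nc1ccc2ccn(Cc3ccc(C(=O)NS(=O)(=O)c4ccccc4)cc3OC)c2c1` gives 8.6 in this assay, and compound 3 `CCCCC(CC)C(=O)Nc1ccc2ccn(Cc3ccc(C(=O)NS(=O)(=O)c4ccc(C)cc4)cc3OC)c2c1` gives 8.4; both numbers lie beyond the scatter below that of compound 1, yet each of these two compounds differs from compound 1 in more than one place, so no single step joins them to it. Within the data shown here, the only single-place step in the set, a number 0.20 log units lower from compound 2 to compound 3 (within the scatter), alters the aryl group on the sulfonyl sulfur and stays within the scatter. Compound 4 `COc1cc(C(=O)NS(=O)(=O)c2ccc3ccccc3c2)ccc1Cn1ccc2ccc(NC(=O)CC3CCCC3)cc21` is not yet measured; it differs from compound 1 by naphthalen-2-yl in place of 2,5-dimethoxyphenyl on a sulfonyl sulfur. Among the measured compounds shown here, this change sits at the same sulfonyl sulfur, where the one measured step was small, but no measured pair makes an exchange of this kind, so the direction rests on thin ground. A modest decrease is expected for compound 4, a number 0.40 log units lower from compound 1 to compound 4 (beyond the scatter). The estimate for compound 4 in this assay is 8.7, expected to fall between 8.1 and 9.3.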

Compound 4, negative logarithm of the antagonist equilibrium constant: 8.3
The estimate for compound 4 lay 0.40 log units above the measured number; the measured number falls inside the stated range.
By their numbers in this assay, from the lowest: compounds 4, 3 and 2 (each within the scatter of the next); then compound 1.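

On the core of compound 1, the aryl group at the sulfonyl sulfur matters in this assay: the exchange gives a number 0.80 log units lower from compound 1 to compound 4 (beyond the scatter) and lies beyond the scatter, whereas the earlier step of a number 0.20 log units lower from compound 2 to compound 3 (within the scatter) stayed within it. The two groups have the same heavy-atom count, but naphthalen-2-yl brings a second six-membered aromatic ring of carbon only and has no hydrogen-bond acceptors, while 2,5-dimethoxyphenyl has two. No measurement in hand accounts for the loss of potency.

From the compounds shown here alone, these differences come together in compound 4, so whether either alone carries the step stays open. Also open, going by these compounds, is how this assay would read an amine or a carboxylic acid on the aryl group at the sulfonyl sulfur of compound 1.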